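Chain Branching in a Weakly Active Series

The source may report more compounds than this note shows. Statements on the series, on what has been measured and on what is new or still open speak of the compounds shown alone.

Compound 1, `CCCc1nc(C)c2c(C(C)C)nnc(O)n12`, in a functional assay for inhibition, with Homo sapiens as the target (on this read-out lower numbers stand for stronger inhibition and higher numbers for weaker inhibition), sits at the assay limit of > 48000 nM.
Compound 2, `CCCc1nc(C)c2cnnc(O)n12`, in this assay gives 56800 nM.
Compound 3, `CCCc1nc(C)c2cnnc(SC)n12`, in this assay sits at the assay limit of > 48000 nM.

Compound 2 is the only one of the three that yields an actual number in this assay; the other two values are limits, not measurements. Because of this, the step that the limit leaves unreadable from compound 1 to compound 2 and the step that the limit leaves unreadable from compound 2 to compound 3 cannot be sized, as the line the limit of > 48000 nM in this assay, at which 2 of the 3 values shown sit, makes plain.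

The unmeasured compound 4, `Cc1nc(CC(C)(C)C)n2c(O)nncc12`, differs from compound 2 by tert-butyl in place of ethyl on a saturated chain carbon bound to an aromatic carbon. Among the compounds with values here, none of the measured steps touches the chain on that carbon, and those steps that do exist are unreadable in size, so no measured change points either way. The weak activity of compound 2 in this assay is the only anchor.

For compound 4 the expected value in this assay is 60000 nM, within 20000 nM to 200000 nM. The estimated step of a 1.1-fold higher number from compound 2 to compound 4 (0.02 log units; within the scatter) is expected to stay within the scatter, with a real chance that only a limit is reported.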

Compound 4, half-maximal inhibitory concentration: > 48000 nM
Compound 4: only a limit was reported; the forecaster's own chance of this, stated with the estimate: 55%; the middle value does not contradict the limit.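

In this assay compound 4 gives > 48000 nM, which is a limit and not a number. No size can be read for the change from compound 2 to compound 4, because the result for compound 4 is only a limit: the limit of > 48000 nM in this assay, at which 3 of the 4 values shown sit.

Still open, going by these compounds, is whether tert-butyl in place of ethyl on this chain strengthens, weakens or leaves unchanged the inhibition seen with compound 2.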